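A Piperazine Swapped for a Methoxybenzylamine

The compounds below may be only part of what the source reports. "The series", "measured", "known", "first", "only" and "open" are said of these compounds alone.

Of the compounds shown here, two have so far been tested in a functional assay on L02 cells (Homo sapiens) for inhibition, read by Griess assay, with stated times of 1 h and 24 h; a higher number here means a weaker inhibitor, a lower number a stronger inhibitor. Compound 1 `CCCc1nn(C)c2c(NC(C)C)nc(/C=C/c3nc(C)c(C)nc3C)nc12` gives 342000 nM. Compound 2 `CCN1CCN(c2nc(/C=C/c3cc(OC)c(OC)c(OC)c3)nc3ccsc23)CC1` gives only a limit of the assay, > 1000000 nM. Compound 2 thus stands at the weak end of the numbers seen, as the limit of > 1000000 nM in this assay, at which 1 of the 2 values shown sits, records. Compound 3 `COc1ccc(CNc2nc(/C=C/c3cc(OC)c(OC)c(OC)c3)nc3ccsc23)cc1` is the next structure, differing from compound 2 in one place: (4-methoxybenzyl)amino in place of 4-ethylpiperazin-1-yl on an aromatic carbon. Within the data shown here, no measured step of this kind exists here, so the expected change an at least 1.2-fold lower number from compound 2 to compound 3 (0.09 log units; that floor lies within the scatter) is put within the scatter, with a slight lean toward stronger inhibition. Compound 3 is therefore estimated at 800000 nM, between 300000 nM and 1500000 nM.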

Compound 3, half-maximal inhibitory concentration: > 1000000 nM
Compound 3 was reported as a limit; the forecaster's own chance of this, stated with the estimate: 50%; middle value at least 1.2-fold (0.09 log units) away from the limit.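

Compound 2 and compound 3 are both reported only as limits, not as numbers, so no step can be read between them. As far as these compounds go, how far (4-methoxybenzyl)amino in place of 4-ethylpiperazin-1-yl shifts inhibition in this assay stays open.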